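Carboxy on the pendant ring of compound 3

The source may report more compounds than this note shows. Statements on the series, on what has been measured and on what is new or still open speak of the compounds shown alone.

Compound 3 `CCCCCCCCc1ccc(OCC(=O)Cn2nnnc2-c2ccccc2)cc1` gives 71 nM in an assay on microsomes from brain for inhibition of Fatty-acid amide hydrolase 1 (Rattus norvegicus), read by fluorescence and HPLC, with a stated time of 60 min (on this read-out lower numbers stand for stronger inhibition and higher numbers for weaker inhibition), the highest of the three numbers measured. Compound 1 `CCCCCCCCc1ccc(OCC(=O)Cn2nnc(-c3ccccc3)n2)cc1` gives 24 nM and compound 2 `CCCCCCCCc1ccc(OCC(=O)Cn2nnc(-c3cccnc3)n2)cc1` gives 23 nM, both beyond the scatter below compound 3. Compound 4 `CCCCCCCCc1ccc(OCC(=O)Cn2nnnc2-c2cccc(C(=O)O)c2)cc1` differs from compound 3 by carboxy in place of hydrogen on an aromatic carbon. Among the compounds with values here, the only measured step, a 1.0-fold lower number from compound 1 to compound 2 (0.02 log units; within the scatter), changes the pendant ring without moving the number, but it swaps a ring atom rather than adding a carboxy group, so it bears only loosely here. Within the data shown here, no measured pair adds a carboxy group. Compound 4 is therefore expected near compound 3, with a small weakening allowed, as a 1.5-fold higher number from compound 3 to compound 4 (0.19 log units; within the scatter). Compound 4 is estimated at 110 nM, between 35 nM and 350 nM.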

Compound 4, half-maximal inhibitory concentration: 1800 nM
Compound 4: the middle estimate sits 16-fold (1.21 log units) below what was measured; measured number above the stated range.
By their numbers in this assay, from the lowest: compounds 2 and 1 (each within the scatter of the next); then compound 3; then compound 4.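

The pendant phenyl ring of compound 3 is not indifferent to substitution: replacing phenyl with 3-carboxyphenyl gives a 25-fold higher number from compound 3 to compound 4 (1.40 log units; beyond the scatter) in this assay. A single carboxy group at this position, meta to a large group, is thus enough to weaken inhibition well beyond the scatter. No measurement at hand says why the number rises so far.

The compounds shown leave open whether a methyl ester, an amide or a hydroxymethyl group on the same carbon would cost as much, and whether carboxy elsewhere on this ring would do the same.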